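The source may report more compounds than this note shows. Statements on the series, on what has been measured and on what is new or still open speak of the compounds shown alone.

The study compares three measured compounds and one that is not yet measured, all built on a shared core. Compound 1 `Cc1ccccc1-c1cc2cc([N+](=O)[O-])ccc2[nH]1` gives 71.5% in an assay on isolated protein for inhibition of Aromatase (Homo sapiens), read by fluorescence, using NADPH, with a stated time of 30 min, tested at 50 uM; a lower number here means less inhibition, a higher number more inhibition at the concentration tested (going by the name of the read-out); compound 3 `Nc1cccc(-c2cc3ccccc3[nH]2)c1` gives 26.7% in the same test; and compound 2 `c1ccc(Cn2c(-c3ccccc3)cc3ccccc32)cc1` gives 0%. Compound 2 thus stands lowest of the three numbers, with compound 3 nearest to it and compound 1 furthest away, both gaps lying beyond the usual scatter of repeated runs. The unmeasured compound 4 `COCn1c(-c2ccccc2)cc2ccccc21` differs from compound 2 in a single place: methoxy in place of phenyl on a saturated chain carbon bound to an aromatic nitrogen. Cut one bond further out, the change reads benzyl to methoxymethyl, so the saturated chain carbon bound to the aromatic nitrogen keeps its substituent, only with methoxy where phenyl stood. Among the measured compounds shown here, no measured pair here isolates such a change, so the step can only be expected, not read off. The expectation for compound 4 is a small upward step of a number 10 percentage points higher from compound 2 to compound 4 (within the scatter) from the zero of compound 2, a shift that may well remain within the scatter. Compound 4 is therefore estimated at 10% in this assay, with a range from 0% to 35%.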

Compound 4, a percentage reported as inhibition, at one concentration (the size of the read-out at that concentration, not a potency): 20.2%
Compound 4: middle estimate off by 10.2 percentage points, on the low side, within the range that was stated.
By their numbers in this assay, from the lowest: compound 2; then compounds 4 and 3 (each within the scatter of the next); then compound 1.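

Methoxy in place of phenyl on a saturated chain carbon bound to an aromatic nitrogen gives, in this assay, a number 20.2 percentage points higher from compound 2 to compound 4 (beyond the scatter), and this is the first step in the series that isolates a change in one place. It shows that the zero of compound 2 does not hold for every group at this position: with the phenyl ring gone and methoxy in its place, compound 4 gives 20.2%, so a ring of carbon is not needed here for a measurable reading at the concentration tested. Nothing at hand bears on why the number moves, and the step records only that it does.

The compounds shown leave open whether the step goes with the loss of the phenyl ring or with the entry of the oxygen, since this one change does both at once. A plain ethyl or a longer alkyl chain at the same place would pull those two apart, while an amine or a carboxylic acid on that chain would test how far the step extends to other groups.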